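The source may report more compounds than this note shows. Statements on the series, on what has been measured and on what is new or still open speak of the compounds shown alone.

Compound 3 `O=C(Nc1ccccc1Br)N[C@H]1CC[C@H](Oc2ccc(F)cc2)CC1` gives 7700 nM in a functional assay on CRL2813 cells (Homo sapiens) for cytotoxicity, read by sulforhodamine B assay, with a stated time of 5 days (a higher number here means a weaker inhibitor, a lower number a stronger inhibitor), the lowest of the two numbers in hand; compound 2 `O=C(Nc1cccc(F)c1)N[C@H]1CC[C@H](Oc2ccc(F)cc2)CC1` gives 8300 nM, and the gap, a 1.1-fold lower number from compound 2 to compound 3 (0.03 log units; within the scatter), is within the scatter, so no order between the two is claimed. Compound 1 `COc1ccccc1NC(=O)N[C@H]1CC[C@H](Oc2ccc(F)cc2)CC1` reaches only a limit of this assay, > 20000 nM (the limit of > 20000 nM in this assay, at which 1 of the 3 values shown sits). From compound 1 the steps are an at least 2.4-fold lower number from compound 1 to compound 2 (0.38 log units; beyond the scatter) and an at least 2.5-fold lower number from compound 1 to compound 3 (0.41 log units; beyond the scatter). Compound 4 `O=C(Nc1ccccc1Cl)N[C@H]1CC[C@H](Oc2ccc(F)cc2)CC1` differs from compound 3 by chloro in place of bromo on an aromatic carbon. Going by the values given here, no measured step exchanges one halogen for another on that ring; the nearest, a 1.1-fold lower number from compound 2 to compound 3 (0.03 log units; within the scatter), moved a halogen between positions without leaving the scatter. The step expected is therefore none beyond the scatter, a 1.0-fold higher number from compound 3 to compound 4 (0.02 log units; within the scatter). Compound 4 is expected near 8000 nM, between 4000 nM and 16000 nM.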

Compound 4, half-maximal inhibitory concentration: 9100 nM
The estimate for compound 4 lay 1.1-fold (0.06 log units) below the measured number, and the stated range covers the measured number.
By their numbers in this assay, from the lowest: compounds 3, 2 and 4 (each within the scatter of the next). At a limit, above all of these: compound 1.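

Bromo and chloro on an aromatic carbon ortho to a large group are not told apart in this assay: a 1.2-fold higher number from compound 3 to compound 4 (0.07 log units; within the scatter) is the first direct exchange of one halogen for another here. The 2-chlorophenyl and 3-fluorophenyl groups also stay together, with a 1.1-fold higher number from compound 2 to compound 4 (0.04 log units; within the scatter). Chloro in place of methoxy gives an at least 2.1-fold lower number from compound 1 to compound 4 (0.34 log units; beyond the scatter), a step read from a limit for compound 1: the limit of > 20000 nM in this assay, at which 1 of the 4 values shown sits.

Open, on these data alone, is how an amine or a carboxylic acid on this carbon would read in this assay. Also open, as far as these compounds go, is where compound 1 truly lies.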